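The source may report more compounds than this note shows. Statements on the series, on what has been measured and on what is new or still open speak of the compounds shown alone.

Working notes on a short series sharing one core, varied at the group on a carbonyl carbon. Compound 1 `CCOC(=O)N1CC[C@H](c2ccc(Cl)cc2)[C@H]1C(=O)N1CCN(c2ccc(C)cc2[C@@H](N)C(C)C)CC1` carries ethoxy there, and in an assay on HEK293 cells for displacement of a labelled ligand from Melanocortin receptor 4 (Homo sapiens) (on this read-out lower numbers stand for stronger inhibition and higher numbers for weaker inhibition), compound 1 gives 42 nM. Compound 2 `Cc1ccc(N2CCN(C(=O)[C@@H]3[C@@H](c4ccc(Cl)cc4)CCN3C(=O)OC(C)C)CC2)c([C@@H](N)C(C)C)c1` carries isopropoxy, and in this assay compound 2 gives 68 nM. Compound 3 `CCC(=O)N1CC[C@H](c2ccc(Cl)cc2)[C@H]1C(=O)N1CCN(c2ccc(C)cc2[C@@H](N)C(C)C)CC1` carries ethyl on the carbonyl carbon, and in this assay compound 3 gives 62 nM. Among the three numbers compound 3 stands second highest, nearest to compound 2 and furthest from compound 1, with all three within the scatter of one another: a 1.6-fold higher number from compound 1 to compound 2 (0.21 log units; within the scatter), a 1.5-fold higher number from compound 1 to compound 3 (0.17 log units; within the scatter) and a 1.1-fold lower number from compound 2 to compound 3 (0.04 log units; within the scatter).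

The next compound is compound 4 `CCCC(=O)N1CC[C@H](c2ccc(Cl)cc2)[C@H]1C(=O)N1CCN(c2ccc(C)cc2[C@@H](N)C(C)C)CC1`, which differs from compound 3 by methyl in place of hydrogen on a saturated chain carbon, two bonds along the chain from a carbonyl carbon. For the measured compounds named here, no measured step matches this exact change. Going by the values given here, the nearest precedent is a 1.6-fold higher number from compound 1 to compound 2 (0.21 log units; within the scatter), which, like the change to compound 4, adds a methyl on a saturated chain carbon. That step, and the exchanges of ethoxy or isopropoxy for ethyl in a 1.5-fold higher number from compound 1 to compound 3 (0.17 log units; within the scatter) and a 1.1-fold lower number from compound 2 to compound 3 (0.04 log units; within the scatter), all stayed within the scatter. Hence no step beyond the scatter is expected in this assay. The expected change is a 1.0-fold higher number from compound 3 to compound 4 (0.02 log units; within the scatter). Compound 4 is estimated at 65 nM, with a likely range from 30 nM to 140 nM.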

Compound 4, inhibition constant: 52 nM
For compound 4 the middle estimate is 1.3-fold (0.10 log units) above the measured one; the range from low to high includes it.
By their numbers in this assay, from the lowest: compounds 1, 4, 3 and 2 (each within the scatter of the next).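

Extending the ethyl on the carbonyl carbon to propyl, with methyl in place of hydrogen on a saturated chain carbon, two bonds along the chain from a carbonyl carbon, leaves the number in this assay within the scatter: a 1.2-fold lower number from compound 3 to compound 4 (0.08 log units; within the scatter). Propyl also stays within the scatter of the ethoxy and isopropoxy groups, with a 1.2-fold higher number from compound 1 to compound 4 (0.09 log units; within the scatter) and a 1.3-fold lower number from compound 2 to compound 4 (0.12 log units; within the scatter), so the four groups on this carbonyl carbon, with oxygen or carbon bound to it, cannot be told apart on this read-out. The addition of a methyl can now be read on two cores, and the two steps do not separate from each other: the same change on two cores in this assay, a 1.6-fold higher number (0.21 log units; within the scatter) from compound 1 to compound 2 and a 1.2-fold lower number (0.08 log units; within the scatter) from compound 3 to compound 4, 1.9-fold (0.29 log units) apart, within the scatter of two such steps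

The compounds shown leave open whether a longer chain, a phenyl ring, an amine or a carboxylic acid on this carbonyl carbon would give a step beyond the scatter. For the compounds shown here, with every step so far within the scatter, they also give no indication of which feature of this group, if any, the number in this assay responds to.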